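Notes on the heteroaryl swap at the thioether

The source may report more compounds than this note shows. Statements on the series, on what has been measured and on what is new or still open speak of the compounds shown alone.

Compound 2 `CCOc1cc2ncnc(Nc3ccc(F)c(Cl)c3)c2cc1OC(=O)CSc1nc2ccccc2n1C` carries the highest of the two numbers seen so far: in a functional assay on NCI-H1975 cells (Homo sapiens) for inhibition, read by MTT assay, with a stated time of 72 h (a higher number here means a weaker inhibitor, a lower number a stronger inhibitor), compound 2 gives 9100 nM. Within the data shown here, its nearest neighbour is compound 1 `CCOc1cc2ncnc(Nc3ccc(F)c(Cl)c3)c2cc1OC(=O)CSc1nccn1C`, which in this assay gives 6900 nM; the only measured step between them, a 1.3-fold higher number from compound 1 to compound 2 (0.12 log units; within the scatter), is within the scatter. Compound 3 `CCOc1cc2ncnc(Nc3ccc(F)c(Cl)c3)c2cc1OC(=O)CSc1nc2cc(OC)ccc2s1` differs from compound 2 by 5-methoxy-1,3-benzothiazol-2-yl in place of 1-methyl-1H-benzimidazol-2-yl on a sulfur. Among the measured compounds shown here, the single step that bears on this change is the one from compound 1 to compound 2, a swap of heteroaryl on the same sulfur, and it stayed within the scatter, so no guide exists for a move of any size beyond it. Compound 3 is therefore expected to show a step of a 1.0-fold lower number from compound 2 to compound 3 (0.00 log units; within the scatter), within the scatter. The number for compound 3 in this assay is estimated at 9000 nM, with a range from 3000 nM to 27000 nM.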

Compound 3, half-maximal inhibitory concentration: 3200 nM
The estimate for compound 3 lay 2.8-fold (0.45 log units) above the measured number, within the range that was stated.
By their numbers in this assay, from the lowest: compound 3; then compounds 1 and 2 (each within the scatter of the next).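

The group on this sulfur now shows an effect in this assay: 5-methoxy-1,3-benzothiazol-2-yl gives a 2.8-fold lower number from compound 2 to compound 3 (0.45 log units; beyond the scatter), and against 1-methyl-1H-imidazol-2-yl it gives a 2.2-fold lower number from compound 1 to compound 3 (0.33 log units; beyond the scatter). Both steps are modest, yet they lie beyond the scatter, whereas compound 1 and compound 2 stay within the scatter of each other, so this position does respond to the choice of heteroaryl, though not to every swap. Nothing available bears on what lies behind this difference.

On these data alone, the change to compound 3 replaces the ring system and adds a methoxy in one move, so the share of each remains open. Also open, as far as these compounds go, is whether plain 1,3-benzothiazol-2-yl, or the same ring carrying an amine or a carboxylic acid instead of the methoxy, would keep the lower number.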